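Bromo for Methoxy on the Aryl Ring of Compound 1

The source may hold more compounds than are shown below. What is called first, only, known or untested is meant among the compounds shown, and "the series" means these compounds.

Measured compounds:
compound 1 `COc1ccc(-n2nc(-c3ccccc3)nc2CNc2ccc(C(=O)NO)cc2)cc1` — an assay on Sf9 cells for inhibition of protein deacetylase HDAC6 (Homo sapiens), read by fluorescence, with a stated time of 40 min; a higher number here means a weaker inhibitor, a lower number a stronger inhibitor: 127 nM
compound 2 `COc1ccc(-n2nc(-c3ccc(O)cc3)nc2CNc2ccc(C(=O)NO)cc2)cc1` — this assay: 102 nM

For the measured compounds named here, compound 1 holds the higher of the two numbers measured so far, but its only neighbour, compound 2, sits close to it: the single measured step, a 1.2-fold lower number from compound 1 to compound 2 (0.10 log units; within the scatter), lies within the scatter, so the two compounds cannot be ranked against each other.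

Compound 3 `O=C(NO)c1ccc(NCc2nc(-c3ccccc3)nn2-c2ccc(Br)cc2)cc1` has not yet been measured. It differs from compound 1 by bromo in place of methoxy on an aromatic carbon. Going by the values given here, no measured step concerns this change; the only step available, from compound 1 to compound 2, replaces hydrogen by hydroxy and stays within the scatter, so it offers no guide to the size or direction of the present step. With nothing in the data pointing either way, the step from compound 1 to compound 3 is expected to remain small, a 1.1-fold lower number from compound 1 to compound 3 (0.02 log units; within the scatter), and to lie within the scatter. Compound 3 is therefore estimated at 120 nM in this assay, with a range from 50 nM to 300 nM.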

Compound 3, half-maximal inhibitory concentration: 1730 nM
Compound 3: middle estimate off by 14-fold (1.16 log units), on the low side, and the stated range ends below it.
By their numbers in this assay, from the lowest: compounds 2 and 1 (each within the scatter of the next); then compound 3.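

In this assay the change from 4-methoxyphenyl to 4-bromophenyl gives a 14-fold higher number from compound 1 to compound 3 (1.13 log units; beyond the scatter) and is the only step shown that lies beyond the scatter, so this position, para to a large group, responds strongly to the exchange of these two groups. For the compounds shown here, the earlier step, a 1.2-fold lower number from compound 1 to compound 2 (0.10 log units; within the scatter) with hydroxy in place of hydrogen at another aromatic carbon, gave no such sign and left compound 1 and compound 2 unranked, so the change in compound 3 is the first evidence that the series can move by a large margin in this assay. No measured evidence is available that explains this difference between methoxy and bromo.

The compounds shown do not separate the loss of methoxy from the arrival of bromo, and it remains open whether hydrogen, fluoro, chloro or ethoxy at this position would give a number closer to compound 1 or to compound 3. From the compounds shown here alone, it is also open whether a hydroxy on the phenyl group would have as little effect with 4-bromophenyl in place as it has with 4-methoxyphenyl.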